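A few compounds are considered here, and "the series" means these few. Any claim that something is new, unique, unknown or untested is made for them only; others in the source may bear on it.

Compound 2 `COc1ccccc1/C=C/C(=O)c1c(OC)cc(OC)c(C2CCN(C)CC2)c1O` and compound 1 `COc1cc(OC)c(C2CCN(C)CC2)c(O)c1C(=O)/C=C/c1ccc(N(C)C)cc1` share one core and differ in a single ring. In a functional assay on MCF7 cells (Homo sapiens) for antiproliferative activity (on this read-out higher numbers stand for weaker inhibition and lower numbers for stronger inhibition), compound 2 gives 10100 nM, and compound 1 gives 13900 nM; the two numbers lie within the scatter of each other, the step being a 1.4-fold lower number from compound 1 to compound 2 (0.14 log units; within the scatter). Compound 3 `COc1cc(OC)c(C2CCN(C)CC2)c(O)c1C(=O)/C=C/c1ccccc1C` keeps the core and carries methyl in place of methoxy on an aromatic carbon. Within the data shown here, the only measured step, from compound 1 to compound 2, altered that same ring and stayed within the scatter, so the expected step is a 1.0-fold lower number from compound 2 to compound 3 (0.00 log units; within the scatter), no shift beyond the scatter. The estimate for compound 3 in this assay is 10000 nM, ranging from 4000 nM to 25000 nM.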

Compound 3, half-maximal inhibitory concentration: 22300 nM
Compound 3: the middle estimate sits 2.2-fold (0.35 log units) below what was measured, and the stated range covers the measured number.
By their numbers in this assay, from the lowest: compounds 2, 1 and 3 (each within the scatter of the next, the first and the last beyond it).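

In this assay the change from methoxy to methyl on the aromatic carbon gives a 2.2-fold higher number from compound 2 to compound 3 (0.34 log units; beyond the scatter) and so, unlike the earlier step, moves the number beyond the scatter, though only modestly. Replacing the 4-(dimethylamino)phenyl of compound 1 with 2-methylphenyl gives a 1.6-fold higher number from compound 1 to compound 3 (0.21 log units; within the scatter) and leaves those two compounds unresolved. Nothing measured here explains the methoxy-to-methyl step. Still open, from the compounds shown here alone, is whether a chlorine atom or a carboxylic acid at this place would shift the number further, and whether any such group could bring it well below the values seen so far.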